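Carbamate in place of the aryl amide: compound 4

A few compounds are considered here, and "the series" means these few. Any claim that something is new, unique, unknown or untested is made for them only; others in the source may bear on it.

Compound 1 `Cc1cc(C(=O)Nc2c(F)cccc2F)nn1Cc1cc(Cl)ccc1OCc1ccccc1` gives 10 nM in an assay on CHO-K1 cells for displacement of a labelled ligand from prostaglandin E2 receptor EP1 subtype (Homo sapiens) (on this read-out higher numbers stand for weaker inhibition and lower numbers for stronger inhibition), the lowest of the three numbers in hand. Compound 3 `Cc1cc(NC(=O)c2c(F)cccc2F)nn1Cc1cc(Cl)ccc1OCc1ccccc1` gives 12.6 nM, and a 1.3-fold higher number from compound 1 to compound 3 (0.10 log units; within the scatter). Compound 2 `Cc1cc(NC(=O)C2CCOC2)nn1Cc1cc(Cl)ccc1OCc1ccccc1` gives 39.8 nM, and a 4.0-fold higher number from compound 1 to compound 2 (0.60 log units; beyond the scatter). Compound 4 `CCOC(=O)Nc1cc(C)n(Cc2cc(Cl)ccc2OCc2ccccc2)n1` differs from compound 1 by (ethoxycarbonyl)amino in place of (2,6-difluorophenyl)carbamoyl on an aromatic carbon. The step from compound 1 to compound 2 bears on this: there too the group with a six-membered aromatic ring was exchanged for one without a ring, and the number rose modestly. The same direction appears in a 3.2-fold lower number from compound 2 to compound 3 (0.50 log units; beyond the scatter). A modest rise beyond the scatter is therefore expected for compound 4, a 4.0-fold higher number from compound 1 to compound 4 (0.60 log units; beyond the scatter). The estimate for compound 4 in this assay is 40 nM, with a range of 15 nM to 120 nM.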

Compound 4, half-maximal inhibitory concentration: 79.4 nM
Compound 4: middle estimate off by 2.0-fold (0.30 log units), on the low side; low and high end bracket the measured number.
By their numbers in this assay, from the lowest: compounds 1 and 3 (each within the scatter of the next); then compounds 2 and 4 (each within the scatter of the next).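

In this assay, (ethoxycarbonyl)amino on this aromatic carbon gives a larger rise than the earlier change to an oxolan-3-yl amide: a 7.9-fold higher number from compound 1 to compound 4 (0.90 log units; beyond the scatter), and a 6.3-fold higher number from compound 3 to compound 4 (0.80 log units; beyond the scatter). Ethoxy and oxolan-3-yl on the carbonyl carbon remain unseparated, with a 2.0-fold higher number from compound 2 to compound 4 (0.30 log units; within the scatter), so both groups lacking the six-membered aromatic ring stand apart from 2,6-difluorophenyl. No measurement at hand explains these steps.

Still open, from the compounds shown here alone, is whether the aromatic ring or its two fluorines carries the difference, which phenyl or phenoxy on the same carbonyl carbon could address. Going by these compounds, whether butoxy would behave like ethoxy also remains open.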